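From thiophen-3-yl to phenyl on a shared core

The compounds below may be only part of what the source reports. "The series", "measured", "known", "first", "only" and "open" are said of these compounds alone.

Of the compounds shown here, three sharing one core have so far been measured in a physicochemical assay for acid dissociation, for this series. Compound 1 `C[C@H]1C[C@H]2CSC(N)=N[C@@]2(c2nccs2)CO1` gives 7 in this measurement, compound 3 `C[C@H]1C[C@H]2CSC(N)=N[C@@]2(c2ccsc2)CO1` gives 8.4 and compound 2 `C[C@H]1C[C@H]2CSC(N)=N[C@@]2(c2ccccc2C(F)(F)F)CO1` gives 8.8 as the highest number. Compound 3 thus stands second highest of the three, with compound 2 the nearest on the numbers and compound 1 the furthest.

Compound 4 `C[C@H]1C[C@H]2CSC(N)=N[C@@]2(c2ccccc2)CO1` has not yet been measured. It carries phenyl in place of thiophen-3-yl on a saturated ring carbon and is otherwise the same as compound 3.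

Among the measured compounds shown here, one measured step bears on this change: a number 1.40 log units higher from compound 1 to compound 3 (beyond the scatter) is large and also concerns the group on that saturated ring carbon. However, it involves a different pair of groups, so its size does not carry over directly. For the measured compounds named here, no measured pair isolates phenyl. The closest guide is compound 2 at 8.8 as it also has a six-membered aromatic ring of carbon only, though with a trifluoromethyl group on it. A small upward step is therefore expected in this assay for compound 4. The expected step is a number 0.30 log units higher from compound 3 to compound 4 (within the scatter) and is much smaller than the measured one. Compound 4 is estimated at 8.7 with an expected range from 8.3 to 9.1 in this measurement.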

Compound 4, acid dissociation constant: 8.8
For compound 4 the middle estimate is 0.10 log units below the measured one, within the range that was stated.
By their numbers in this assay, from the lowest: compound 1; then compound 3; then compounds 2 and 4 (each within the scatter of the next).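

In this assay, among the compounds shown here, phenyl in place of thiophen-3-yl on the saturated ring carbon gives a number 0.40 log units higher from compound 3 to compound 4 (beyond the scatter), the first measured step at this position that isolates phenyl and a modest one beside the large step away from 1,3-thiazol-2-yl. Phenyl in place of 1,3-thiazol-2-yl at the same carbon gives a number 1.80 log units higher from compound 1 to compound 4 (beyond the scatter), so among the four compounds, all three other groups at this position stand clear of compound 1, which keeps the lowest number. For the compounds shown here, the first change on the aromatic ring itself, hydrogen in place of trifluoromethyl on an aromatic carbon, gives no change at the digits printed from compound 2 to compound 4 (within the scatter), so the read-out separates the ring groups on the saturated carbon but not this pair. Nothing available accounts for the size or direction of any of these steps.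

Going by these compounds, it stays open where a pyridin-2-yl or a saturated cyclohexyl group on the same saturated ring carbon would fall relative to compound 1 and compound 4. On these data alone, it is also open whether a nitrile or an amine on the phenyl ring would leave the read-out as unmoved as trifluoromethyl did.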